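Lengthening the chain of compound 3

The source may report more compounds than this note shows. Statements on the series, on what has been measured and on what is new or still open speak of the compounds shown alone.

In a functional assay on Bel-7402 cells (Homo sapiens) for inhibition, read by MTT assay, with a stated time of 72 h (on this read-out lower numbers stand for stronger inhibition and higher numbers for weaker inhibition), compound 1 `Nc1ncnc2c1c(-c1cnc3[nH]ccc3c1)nn2CCCCCCCCC(=O)NO` gives 18900 nM while compound 2 `Nc1nc2cc(-c3nn(CCCCC(=O)NO)c4ncnc(N)c34)ccc2o1` gives 2400 nM and compound 3 `Nc1nc2cc(-c3nn(CCCCCC(=O)NO)c4ncnc(N)c34)ccc2o1` gives 2030 nM on the same scale. Compound 3 thus lies within the scatter of compound 2 and well under compound 1. Compound 4 `Nc1nc2cc(-c3nn(CCCCCCCCC(=O)NO)c4ncnc(N)c34)ccc2o1` extends the chain of compound 3 (3-(hydroxycarbamoyl)propyl in place of hydroxycarbamoyl on a saturated chain carbon, five bonds along the chain from an aromatic nitrogen) at that end. Among the measured compounds shown here, the one measured step bearing on this, a shorter extension of the same chain, is a 1.2-fold lower number from compound 2 to compound 3 (0.07 log units; within the scatter) and it stays within the scatter. From the compounds shown here alone, the longer extension is untested, so the estimate is loose. The expected step is a 1.2-fold higher number from compound 3 to compound 4 (0.09 log units; within the scatter) in this assay and thus none beyond the scatter. For compound 4 the estimated value is 2500 nM with an expected range from 700 nM to 9000 nM in this measurement.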

Compound 4, half-maximal inhibitory concentration: > 100000 nM
Compound 4: no number, only a limit (the forecaster's own chance of this, stated with the estimate: 5%); at least 40-fold (1.60 log units) between middle value and limit.
By their numbers in this assay, from the lowest: compounds 3 and 2 (each within the scatter of the next); then compound 1. At a limit, above all of these: compound 4.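

The value of compound 4 is a limit of the assay, not a number: the limit of > 100000 nM in this assay, at which 1 of the 4 values shown sits. The short extension stayed within the scatter, but this long one does not, giving an at least 49-fold higher number from compound 3 to compound 4 (1.69 log units; beyond the scatter) and an at least 41-fold higher number from compound 2 to compound 4 (1.61 log units; beyond the scatter). Chain length is not the whole story, since the aromatic group on this same long chain also counts: an at least 5.2-fold higher number from compound 1 to compound 4 (0.72 log units; beyond the scatter).

Open, from the compounds shown here alone, is where along the chain the loss sets in, with chains longer than that of compound 3 yet shorter than that of compound 4. Also open, going by these compounds, is how a carboxylic acid in place of the hydroxycarbamoyl end would read.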